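A few compounds are considered here, and "the series" means these few. Any claim that something is new, unique, unknown or untested is made for them only; others in the source may bear on it.

Measured so far: compound 1 `NCCCCc1c[nH]c2c(F)cccc12` gives 6 nM in an assay on isolated protein (urine) for inhibition of Myeloperoxidase (Homo sapiens), with a stated time of 5 min; a higher number here means a weaker inhibitor, a lower number a stronger inhibitor; compound 2 `NCC(N)CCc1c[nH]c2ccc(F)cc12` gives 60 nM in this assay.

Compound 2 holds the higher of the two numbers; compound 1 sits well apart from it, the gap being beyond the scatter. Compound 3 `ONCCCc1c[nH]c2ccc(F)cc12` is the next compound to be measured. Its change from compound 2 is (hydroxyamino)methyl in place of 1,2-diaminoethyl on a saturated chain carbon, two bonds along the chain from an aromatic carbon.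

For the measured compounds named here, no step of this kind has been measured, so the direction is open. Compound 3 is expected to land near compound 2, with a step of a 1.5-fold lower number from compound 2 to compound 3 (0.18 log units; within the scatter) that would not exceed the scatter. The estimate for compound 3 in this assay is 40 nM, between 10 nM and 160 nM.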

Compound 3, half-maximal inhibitory concentration: 11 nM
For compound 3 the middle estimate is 3.6-fold (0.56 log units) above the measured one, and the stated range covers the measured number.
By their numbers in this assay, from the lowest: compounds 1 and 3 (each within the scatter of the next); then compound 2.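

In this assay, the first step read at this position, (hydroxyamino)methyl in place of 1,2-diaminoethyl on a saturated chain carbon, two bonds along the chain from an aromatic carbon, gives a 5.5-fold lower number from compound 2 to compound 3 (0.74 log units; beyond the scatter). The number at this position therefore responds to the change of chain end, although the counts of hydrogen-bond donors and acceptors stay the same. Nothing at hand accounts for the step. The compounds shown leave open which part of the change carries the step. A plain primary amine on the same chain, or a longer chain ending in hydroxyamino, would separate the two.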